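The source may hold more compounds than are shown below. What is called first, only, known or untested is meant among the compounds shown, and "the series" means these compounds.

Measured compounds and values:

Compound 1 `CCOC(=O)CCCCCOc1cccc(CN(C(=O)c2ccc(-c3ccncc3)cc2)C(C)C)c1` in an ADME assay on HepG2 cells (Homo sapiens) for cytotoxicity, read by CellTiter-Glo and resazurin assay, with a stated time of 72 h (on this read-out higher numbers stand for an effect only at larger amounts of compound and lower numbers for an effect already at smaller amounts), gives > 26000 nM, which is a limit of the assay.
Compound 2 `CCOC(=O)CCCCCOc1cccc(CN(C(=O)c2ccc(-c3ccc(C(C)=O)s3)cc2)C(C)C)c1` in this assay gives > 26000 nM, again a limit.
Compound 3 `CCOC(=O)CCCCCOc1cccc(CN(C(=O)c2ccc(-c3ccc4cc[nH]c4c3)cc2)C(C)C)c1` in this assay gives > 26000 nM, also a limit.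

Compound 3 thus stands only at a limit in this assay, and the other two values shown are limits as well: all three sit at the same limit (the limit of > 26000 nM in this assay, at which 3 of the 3 values shown sit). The steps between them are accordingly unreadable: a step that the two limits leave unreadable from compound 1 to compound 2, a step that the two limits leave unreadable from compound 1 to compound 3 and a step that the two limits leave unreadable from compound 2 to compound 3.

Compound 4 `CCOC(=O)CCCCCOc1cccc(CN(C(=O)c2ccc(-c3cc(F)cc(OC)c3)cc2)C(C)C)c1` differs from compound 3 by 3-fluoro-5-methoxyphenyl in place of 1H-indol-6-yl on an aromatic carbon. Among the compounds with values here, the three unreadable steps are the only evidence that bears on this change, and none of them gives a direction or a size. Compound 4 is therefore expected to behave like the three measured compounds, most likely reaching only the limit in this assay, with an estimated value of 30000 nM (range 13000 nM to 70000 nM). The step this estimate means, a step that the limit leaves unreadable from compound 3 to compound 4, is expected to lie within the scatter.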

Compound 4, half-maximal effective concentration: > 26000 nM
Compound 4 was reported as a limit (the forecaster's own chance of this, stated with the estimate: 85%); the middle value lies beyond the limit too.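

Compound 4 sits at the same limit as compound 1, compound 2 and compound 3 in this assay, so no step among these compounds can be read: the limit of > 26000 nM in this assay, at which 4 of the 4 values shown sit. The compounds shown leave open whether any group at this place gives an effect at smaller amounts of compound.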